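Six-ring substituent change on the shared core

The source may hold more compounds than are shown below. What is called first, only, known or untested is meant among the compounds shown, and "the series" means these compounds.

Measured so far:
compound 1, `Nc1nc(Cl)c2ncn([C@H]3CCC[C@H]3CO)c2n1`: 83000 nM
compound 2, `Nc1nc(O)c2ncn([C@H]3CCC[C@H]3CO)c2n1`: a limit only, > 200000 nM

In a functional assay on CCRF-CEM cells (Homo sapiens) for antiproliferative activity (on this read-out higher numbers stand for weaker inhibition and lower numbers for stronger inhibition), compound 1 gives 83000 nM. For compound 2 this assay reports only a limit, > 200000 nM. The step of an at least 2.4-fold higher number from compound 1 to compound 2 (0.38 log units; beyond the scatter) thus rests on that limit (the limit of > 200000 nM in this assay, at which 1 of the 2 values shown sits), and compound 2 stands at the weak end of the two values shown, with no number of its own.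

Compound 3, `Nc1nc(N)c2ncn([C@H]3CCC[C@H]3CO)c2n1`, is not yet measured. It differs from compound 2 by amino in place of hydroxy on an aromatic carbon. No measured step pairs hydroxy with amino in this series; the only step shown is chloro to hydroxy, which gave a higher number. On that thin basis the change is expected to give an estimated step of an at least 2.0-fold lower number from compound 2 to compound 3 (0.30 log units; that floor lies within the scatter). Compound 3 is therefore expected at about 100000 nM, within a range from 30000 nM to 300000 nM.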

Compound 3, half-maximal inhibitory concentration: 90000 nM
Compound 3: the middle estimate sits 1.1-fold (0.05 log units) above what was measured; measured number inside the range.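

In this assay, amino in place of hydroxy on this aromatic carbon, next to the ring nitrogen, gives an at least 2.2-fold lower number from compound 2 to compound 3 (0.34 log units; beyond the scatter), so the hydroxy step is not specific to chloro: a second group also separates from hydroxy. Amino in place of chloro gives a 1.1-fold higher number from compound 1 to compound 3 (0.04 log units; within the scatter), so these two groups are not told apart here, and of the three groups only hydroxy stands apart. Both steps involving hydroxy have only a floor, since compound 2 carries a limit and no number of its own: the limit of > 200000 nM in this assay, at which 1 of the 3 values shown sits.

As far as these compounds go, how far hydroxy lies from the other two groups therefore stays open. Also open, from the compounds shown here alone, is whether any other group on this carbon, such as methoxy, methylamino or plain hydrogen, would move the read-out away from the level shared by compound 1 and compound 3.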